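Trading Chloro for Methoxy: What Inhibition to Expect

This account rests on a few compounds, and the source may have more. Where it says the series, first, only, none or still open, it means among the compounds named here.

Measured so far:
Compound 1, `Cn1c(Cn2c(-c3ccccc3)nc3ccccc32)n[nH]c1=S`: 5%
Compound 2, `CNc1nnc(Cn2c(-c3ccc(Cl)cc3)nc3ccccc32)s1`: 21%

Of the compounds shown here, two have been tested in a functional assay for inhibition, tested at 0.1 mM; a lower number here means less inhibition, a higher number more inhibition at the concentration tested (going by the name of the read-out). In this assay compound 1 gives 5%. Compound 2 gives 21%, the higher of the two numbers. The gap between compound 2 and compound 1 lies beyond the usual scatter of such measurements.

Compound 3, `CNc1nnc(Cn2c(-c3ccc(OC)cc3)nc3ccccc32)s1`, is the next compound to be measured. It differs from compound 2 in a single place: methoxy in place of chloro on an aromatic carbon. For the measured compounds named here, no pair of already measured compounds shows this same exchange, so there is no measured step to lean on. The expectation is therefore a small step in this assay, most likely within the scatter, with a slight lean downward rather than upward. Compound 3 is expected to give about 15%, with a plausible range from 3% to 30%. This estimate corresponds to an expected step of a number 6 percentage points lower from compound 2 to compound 3 (within the scatter).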

Compound 3, a percentage reported as inhibition, at one concentration (the size of the read-out at that concentration, not a potency): 5%
The estimate for compound 3 lay 10 percentage points above the measured number; the measured number falls inside the stated range.
By their numbers in this assay, from the lowest: compounds 1 and 3 (each within the scatter of the next); then compound 2.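

Putting methoxy in place of chloro on the aromatic carbon gives a number 16 percentage points lower from compound 2 to compound 3 (beyond the scatter) in this assay and so shows that the read-out responds to what sits at this place on the phenyl ring. Compound 1 and compound 2 differ in more than one place, so that earlier pair could not isolate the effect of this single exchange. What lies behind the lower number cannot be said from any measurement available here.

From the compounds shown here alone, it remains open whether the lower number belongs to methoxy in particular or would also appear with another group at this place, such as a fluorine atom, a hydroxyl or an amine. A single pair at one test concentration gives one step rather than a trend, and it gives no potency.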